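Cycloheptyl in place of 4-fluorophenyl on the ring nitrogen

The compounds below may be only part of what the source reports. "The series", "measured", "known", "first", "only" and "open" are said of these compounds alone.

Compound 1 `CCn1c(-c2ccc(OCc3c(-c4c(Cl)cccc4Cl)noc3C(C)C)cc2)nc2ccc(C(=O)O)cc21`: 2.31 nM
Compound 2 `CC(C)c1onc(-c2c(Cl)cccc2Cl)c1COc1ccc(-c2nc3ccc(C(=O)O)cc3n2C2CC2)cc1`: 16.5 nM
Compound 3 `CC(C)c1onc(-c2c(Cl)cccc2Cl)c1COc1ccc(-c2nc3ccc(C(=O)O)cc3n2-c2ccc(F)cc2)cc1`: 32.2 nM

In an assay on Huh-7 cells for agonist activity at Bile acid receptor (Homo sapiens), read by a luciferase reporter (on this read-out lower numbers stand for an effect already at smaller amounts and higher numbers for an effect only at larger amounts of compound), compound 3 gives the highest of the three numbers; compound 2 sits within the scatter of it (a 2.0-fold higher number from compound 2 to compound 3 (0.29 log units; within the scatter)), whereas compound 1 lies well apart (a 14-fold higher number from compound 1 to compound 3 (1.14 log units; beyond the scatter)). Compound 4 `CC(C)c1onc(-c2c(Cl)cccc2Cl)c1COc1ccc(-c2nc3ccc(C(=O)O)cc3n2C2CCCCCC2)cc1` differs from compound 3 by cycloheptyl in place of 4-fluorophenyl on an aromatic nitrogen. Going by the values given here, the steps that bear on this change are the two from compound 1, a 7.1-fold higher number from compound 1 to compound 2 (0.85 log units; beyond the scatter) and a 14-fold higher number from compound 1 to compound 3 (1.14 log units; beyond the scatter), which both raised the number, while the exchange between the two groups other than ethyl, a 2.0-fold higher number from compound 2 to compound 3 (0.29 log units; within the scatter), stayed within the scatter. A further exchange of one seven-atom group for another is therefore expected to give a step of about a 1.6-fold higher number from compound 3 to compound 4 (0.19 log units; within the scatter) in this assay, possibly none beyond the scatter. Compound 4 is estimated at 50 nM, with a range from 15 nM to 200 nM.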

Compound 4, half-maximal effective concentration: 14.8 nM
Compound 4: middle estimate off by 3.4-fold (0.53 log units), on the high side, and the stated range ends above it.
By their numbers in this assay, from the lowest: compound 1; then compounds 4, 2 and 3 (each within the scatter of the next, the first and the last beyond it).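

In this assay, swapping the aromatic ring for a non-aromatic one of equal heavy-atom count gives a 2.2-fold lower number from compound 3 to compound 4 (0.34 log units; beyond the scatter), a modest step, while a 1.1-fold lower number from compound 2 to compound 4 (0.05 log units; within the scatter) shows that a seven-membered and a three-membered carbon ring cannot be told apart at this nitrogen. Ethyl stays clearly ahead of cycloheptyl, with a 6.4-fold higher number from compound 1 to compound 4 (0.81 log units; beyond the scatter), so among these saturated groups the number does not simply follow ring size. Nothing available explains these differences. As far as these compounds go, whether a longer chain such as propyl, or a ring carrying an amine, would come closer to ethyl remains open.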